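A few compounds are considered here, and "the series" means these few. Any claim that something is new, unique, unknown or untested is made for them only; others in the source may bear on it.

Measured so far in a functional assay on the whole organism (strain Wistar) for inhibition, with Rattus norvegicus as the target, read by paw edema, with a stated time of 30 min, at a dose of 10 mg/kg by the intraperitoneal route; a lower number here means less inhibition, a higher number more inhibition at the dose given (going by the name of the read-out):
compound 1 `O=C(N/N=C/c1cccc(Cl)c1)c1cccnc1Nc1cccc(C(F)(F)F)c1` — 77.8%
compound 2 `COc1cccc(/C=N/NC(=O)c2cccnc2Nc2cccc(C(F)(F)F)c2)c1` — 52.8%

Going by the values given here, compound 2 holds the lower of the two numbers; the single measured step, a number 25 percentage points lower from compound 1 to compound 2 (beyond the scatter), is a swap of one group for another at one place on the ring. Compound 3 `COc1ccc(/C=N/NC(=O)c2cccnc2Nc2cccc(C(F)(F)F)c2)cc1` keeps the same atoms as compound 2 but differs thus: 4-methoxyphenyl in place of 3-methoxyphenyl on a carbon with a double bond to nitrogen. Among the compounds with values here, no measured step moves a group around the ring, so that step supplies no direction here. The change from compound 2 to compound 3 is expected to stay within the scatter, a number 2.2 percentage points higher from compound 2 to compound 3 (within the scatter). Compound 3 is estimated at 55%, between 35% and 75%.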

Compound 3, a percentage reported as inhibition, in the whole organism at one dose (the size of the read-out at that dose, not a potency): 50.4%
For compound 3 the middle estimate is 4.6 percentage points above the measured one; low and high end bracket the measured number.
By their numbers in this assay, from the lowest: compounds 3 and 2 (each within the scatter of the next); then compound 1.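

In this assay, shifting the methoxy around the ring gives a number 2.4 percentage points lower from compound 2 to compound 3 (within the scatter) and so, on this carbon with a double bond to nitrogen, 3-methoxyphenyl and 4-methoxyphenyl are not told apart. The 3-chlorophenyl group keeps its distance from the second methoxy isomer too, with a number 27.4 percentage points lower from compound 1 to compound 3 (beyond the scatter) as the step, so the gap to compound 1 holds for both methoxyphenyl groups. Nothing at hand accounts for either step.

Open, as far as these compounds go, is how 4-chlorophenyl would compare with 3-chlorophenyl at this carbon. Also open, from the compounds shown here alone, is how a phenyl ring carrying an amine or a carboxylic acid would read here.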